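This account rests on a few compounds, and the source may have more. Where it says the series, first, only, none or still open, it means among the compounds named here.

Measured so far:
compound 1 `CCc1cccc(Nc2cc(NC(=O)Nc3cc(OC)cc(OC)c3)ncn2)c1`: 52.6%
compound 2 `COc1cc(NC(=O)Nc2cc(Nc3cc(C)cc(F)c3)ncn2)cc(OC)c1`: 62.1%
compound 3 `COc1cc(NC(=O)Nc2cc(Nc3ccc(Br)cc3OC)ncn2)cc(OC)c1`: 57.7%

In a functional assay on HCC827 cells (Homo sapiens) for inhibition, read by MTT assay, with a stated time of 48 h, tested at 10 uM (on this read-out higher numbers stand for more inhibition at the one concentration tested (going by the name of the read-out) and lower numbers for less inhibition), compound 3 gives 57.7%, the second highest of the three numbers. Its neighbours are close: the step of a number 4.4 percentage points lower from compound 2 to compound 3 (within the scatter) and the step of a number 5.1 percentage points higher from compound 1 to compound 3 (within the scatter) both sit within the scatter, so the three compounds cannot be ranked.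

Compound 4 `COc1cc(NC(=O)Nc2cc(Nc3cc(I)ccc3OC)ncn2)cc(OC)c1` is the next compound; its change from compound 3 is 5-iodo-2-methoxyphenyl in place of 4-bromo-2-methoxyphenyl on a nitrogen on an aromatic ring.

Within the data shown here, the steps that bear on this change are those that swapped the same aromatic group on that nitrogen: a number 9.5 percentage points higher from compound 1 to compound 2 (within the scatter), a number 5.1 percentage points higher from compound 1 to compound 3 (within the scatter) and a number 4.4 percentage points lower from compound 2 to compound 3 (within the scatter). None moved beyond the scatter, so no step beyond the scatter is expected here either.

Compound 4 is therefore expected to give about 58%, in a range from 46% to 70%. This estimate means an expected step of a number 0.3 percentage points higher from compound 3 to compound 4 (within the scatter).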

Compound 4, a percentage reported as inhibition, at one concentration (the size of the read-out at that concentration, not a potency): 71%
The estimate for compound 4 lay 13 percentage points below the measured number; the measured number lies above the stated range.
By their numbers in this assay, from the lowest: compounds 1, 3, 2 and 4 (each within the scatter of the next, the first and the last beyond it).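

In this assay, among these compounds, the group on this nitrogen now makes a difference beyond the scatter: 5-iodo-2-methoxyphenyl gives a number 13.3 percentage points higher from compound 3 to compound 4 (beyond the scatter) and a number 18.4 percentage points higher from compound 1 to compound 4 (beyond the scatter), the first steps at this place to pass it. The step of a number 8.9 percentage points higher from compound 2 to compound 4 (within the scatter) stays within the scatter, so compound 4 does not stand clear of compound 2. Nothing measured here explains the rise.

Bromine and iodine differ in both element and numbered place, and these compounds do not separate the two. As far as these compounds go, how 5-bromo-2-methoxyphenyl, or a phenyl ring carrying an amine, would read on this nitrogen remains open.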